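This account rests on a few compounds, and the source may have more. Where it says the series, first, only, none or still open, it means among the compounds named here.

Among the measured compounds shown here, compound 2, `CCc1ccc(Nc2cc(NC(=O)Nc3cc(OC)cc(OC)c3)ncn2)cc1`, is one of two compounds measured so far in a functional assay on PC-9 cells (Homo sapiens) for inhibition, read by MTT assay, with a stated time of 48 h, tested at 10 uM; a higher number here means more inhibition at the concentration tested (going by the name of the read-out), a lower number less inhibition. In this assay compound 2 gives 78%. Its companion, compound 1, `COc1cc(NC(=O)Nc2cc(Nc3ccc(C(C)(C)C)cc3)ncn2)cc(OC)c1`, carries a tert-butyl group on the same aromatic ring where compound 2 carries an ethyl group; in this assay compound 1 gives 74.1%. For the measured compounds named here, the single step known between them, a number 3.9 percentage points higher from compound 1 to compound 2 (within the scatter), is small, so compound 2 stands alongside compound 1 with no separation that can be trusted.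

Compound 3, `COc1cc(NC(=O)Nc2cc(Nc3ccc(C)c(C)c3)ncn2)cc(OC)c1`, has not yet been measured. It differs from compound 2 in one place: 3,4-dimethylphenyl in place of 4-ethylphenyl on a nitrogen on an aromatic ring. Going by the values given here, the only measured step that bears on this change is the swap of groups on the same ring, from compound 1 to compound 2, which stayed within the scatter. On that slim basis a change of similar size is expected here, and the step from compound 2 to compound 3 is estimated at a number 3 percentage points lower from compound 2 to compound 3 (within the scatter), not beyond the scatter in either direction. Compound 3 is therefore expected to give about 75% in this assay, estimated to fall between 60% and 88%.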

Compound 3, a percentage reported as inhibition, at one concentration (the size of the read-out at that concentration, not a potency): 66%
Estimate against measurement, compound 3: 9 percentage points above; measured number inside the range.
By their numbers in this assay, from the lowest: compounds 3, 1 and 2 (each within the scatter of the next, the first and the last beyond it).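

This position on the nitrogen responds to how atoms are arranged, not only to which atoms are present: 3,4-dimethylphenyl and 4-ethylphenyl have the same atoms joined differently, yet in this assay the swap gives a number 12 percentage points lower from compound 2 to compound 3 (beyond the scatter) and is the one step shown that clears the scatter. Among the compounds shown here, the comparison with the bulkier-named 4-(tert-butyl)phenyl group is less sharp, at a number 8.1 percentage points lower from compound 1 to compound 3 (within the scatter) and so without a separation that can be trusted; since compound 1 also cannot be separated from compound 2, only the pair of compound 2 and compound 3 stands apart. Nothing available explains why this rearrangement of the ring substituents lowers the inhibition read at this position.

Still open, from the compounds shown here alone, is whether one methyl group alone, as in 4-methylphenyl or 3-methylphenyl, would read like compound 2 or like compound 3, which would show which part of the change goes with the step. All three rings shown carry only carbon substituents, so the response of this position to a ring bearing an amine or a carboxylic acid also remains unknown.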